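Changing the aryl amine in a cytotoxic series

The source may hold more compounds than are shown below. What is called first, only, known or untested is meant among the compounds shown, and "the series" means these compounds.

Three compounds have been measured in a functional assay on MCF7 cells (Homo sapiens) for cytotoxicity, read by MTT assay, with a stated time of 72 h; a lower number here means a stronger inhibitor, a higher number a weaker inhibitor:

compound 1, `CCCCCCNc1nc(SCc2ccc(C(F)(F)F)cc2)nc2ccccc12`, gives 24300 nM
compound 2, `CCOc1ccccc1Nc1nc(SCc2ccc(C(F)(F)F)cc2)nc2ccccc12`, gives > 50000 nM, which is a limit of the assay and not a number
compound 3, `FC(F)(F)c1ccc(CSc2nc(Nc3ccc(Cl)cc3)c3ccccc3n2)cc1`, gives 21500 nM

Among the two actual numbers in this assay compound 3 sits lowest, but its gap to compound 1 is within the scatter, so the two cannot be ordered. The step of an at least 2.0-fold higher number from compound 1 to compound 2 (0.31 log units; beyond the scatter) went the other way, and the step of an at least 2.3-fold lower number from compound 2 to compound 3 (0.36 log units; beyond the scatter) reversed it, both beyond the scatter, and the reading for compound 2 is only a limit (the limit of > 50000 nM in this assay, at which 1 of the 3 values shown sits).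

Compound 4, `COc1ccc(Nc2nc(SCc3ccc(C(F)(F)F)cc3)nc3ccccc23)c(OC)c1`, is not yet measured. It differs from compound 3 in this way: 2,4-dimethoxyphenyl in place of 4-chlorophenyl on a nitrogen on an aromatic ring. Among the measured compounds shown here, the nearest precedent is compound 2, bearing 2-ethoxyphenyl, which gave a weaker reading than either compound 1 or compound 3. Compound 4 is therefore expected to give a higher number in this assay, estimated as a step of a 2.1-fold higher number from compound 3 to compound 4 (0.32 log units; beyond the scatter). The estimate for compound 4 in this assay is 45000 nM, between 18000 nM and 110000 nM, with a real chance that only a limit is reported.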

Compound 4, half-maximal inhibitory concentration: > 50000 nM
Compound 4: only a limit was reported; the forecaster's own chance of this, stated with the estimate: 45%; middle value at least 1.1-fold (0.04 log units) away from the limit.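

Replacing 4-chlorophenyl with 2,4-dimethoxyphenyl on the nitrogen gave an at least 2.3-fold higher number from compound 3 to compound 4 (0.36 log units; beyond the scatter), and replacing hexyl with it gave an at least 2.0-fold higher number from compound 1 to compound 4 (0.31 log units; beyond the scatter). The weak reading of the 2-ethoxyphenyl compound is therefore no longer a single case, since both oxygen-bearing aryl groups, in compound 2 and compound 4, now end at a limit and not a number in this assay: the limit of > 50000 nM in this assay, at which 2 of the 4 values shown sit. The two limits leave the step between compound 2 and compound 4 unreadable, so the second oxygen-bearing group cannot be said to help or to harm.

As far as these compounds go, what remains open is whether a single methoxy group, a fluorine or an amine on the aryl ring would still give a number. Also open, from the compounds shown here alone, is whether a benzyl or cyclohexyl group on this nitrogen would move the reading away from those of compound 1 and compound 3.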